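The compounds below may be only part of what the source reports. "The series", "measured", "known", "first", "only" and "open" are said of these compounds alone.

Measured compounds:
- Compound 1 `O=C(NCc1cc(Cl)ccc1-n1cnnn1)[C@@H]1[C@H]2C[C@H]2CN1C(=O)[C@H](O)CC1CC1`: 3.4 10^-6 cm/s
- Compound 2 `CC(C)(C)[C@@H](O)C(=O)N1C[C@@H]2C[C@@H]2[C@H]1C(=O)NCc1cc(Cl)ccc1-n1cnnn1`: 17 10^-6 cm/s
- Compound 3 `O=C(NCc1cc(Cl)ccc1-n1cnnn1)[C@@H]1[C@H]2C[C@H]2CN1C(=O)[C@H](O)C1CCCCC1`: 25 10^-6 cm/s

In an ADME assay on Caco-2 cells (Homo sapiens) for permeability, read by LC-MS, in the apical to basolateral direction, with a stated time of 60 min, at pH 6.5 (on this read-out higher numbers stand for higher permeability and lower numbers for lower permeability), compound 3 gives the highest of the three numbers. Its distance from compound 2 is small, a 1.5-fold higher number from compound 2 to compound 3 (0.17 log units; within the scatter), which is within the scatter, whereas its distance from compound 1 is real, a 7.4-fold higher number from compound 1 to compound 3 (0.87 log units; beyond the scatter). Compound 4 `CC(C)(C)C[C@@H](O)C(=O)N1C[C@@H]2C[C@@H]2[C@H]1C(=O)NCc1cc(Cl)ccc1-n1cnnn1` differs from compound 3 in one place: neopentyl in place of cyclohexyl on a saturated chain carbon bound to a carbonyl carbon and an oxygen on a saturated carbon.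

Among the compounds with values here, the steps that bear on this change are those that replace the cyclopropylmethyl of compound 1: a 5.0-fold higher number from compound 1 to compound 2 (0.70 log units; beyond the scatter) and a 7.4-fold higher number from compound 1 to compound 3 (0.87 log units; beyond the scatter). Both lift the number, yet the two products of those steps, compound 2 and compound 3, are within the scatter of each other, a 1.5-fold higher number from compound 2 to compound 3 (0.17 log units; within the scatter). Neopentyl is a ring-free chain like the tert-butyl of compound 2 rather than a ring like the cyclohexyl of compound 3, so compound 4 is expected to land in the same band as those two, with no step beyond the scatter from compound 3, a 1.3-fold lower number from compound 3 to compound 4 (0.12 log units; within the scatter). The estimated value for compound 4 in this assay is 19 10^-6 cm/s, in a range from 9 10^-6 cm/s to 40 10^-6 cm/s.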

Compound 4, apparent permeability: 25 10^-6 cm/s
Compound 4: the middle estimate sits 1.3-fold (0.12 log units) below what was measured, and the stated range covers the measured number.
By their numbers in this assay, from the lowest: compound 1; then compounds 2, 3 and 4 (each within the scatter of the next).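

In this assay, neopentyl, which has no ring, takes the place of cyclohexyl with no change at the digits printed from compound 3 to compound 4 (within the scatter), so the six-membered ring of compound 3 is not required at this position to hold the number in this band. The comparison with the other ring-free group gives a 1.5-fold higher number from compound 2 to compound 4 (0.17 log units; within the scatter), while a 7.4-fold higher number from compound 1 to compound 4 (0.87 log units; beyond the scatter) leaves the cyclopropylmethyl of compound 1 as the only group shown here that stands apart from the others. Nothing available here explains why compound 1 differs from the other three.

The compounds shown carry only hydrocarbon groups at this position, so it remains open whether an amine or a carboxylic acid would stay in the same band. On these data alone, it is also open whether a longer chain, such as n-hexyl, or a smaller group, such as methyl, would stay there.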